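The compounds below may be only part of what the source reports. "The series", "measured", "known", "first", "only" and "open" are said of these compounds alone.

In a functional assay on A549 cells (Homo sapiens) for inhibition, read by MTT assay, with a stated time of 48 h (a lower number here means a stronger inhibitor, a higher number a weaker inhibitor), compound 1 (`COc1ccc(N(C)c2nc(C)nc3ccccc23)cc1OCCCCCC[Se]C#N`) gives 5520 nM and compound 2 (`COc1ccc(N(C)c2nc(C)nc3ccccc23)cc1C(=O)OCCC[Se]C#N`) gives 250 nM, the lower of the two numbers. Compound 3 (`COc1ccc(N(C)c2nc(C)nc3ccccc23)cc1[Se]C`) makes a much bigger cut: a group of 2 heavy atoms (1 carbon, 1 selenium; no ring) in place of a group of 9 heavy atoms (5 carbon, 1 nitrogen, 2 oxygen, 1 selenium; no ring), on an aromatic carbon. Within the data shown here, the only measured step, a 22-fold lower number from compound 1 to compound 2 (1.34 log units; beyond the scatter), is large and also replaced one group with a somewhat smaller one. A single step sets no rule, but it points towards a further fall of uncertain size. The expected change is a 3.6-fold lower number from compound 2 to compound 3 (0.55 log units; beyond the scatter). In this assay, the estimated value for compound 3 is 70 nM, with an expected range of 8 nM to 600 nM.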

Compound 3, half-maximal inhibitory concentration: 11 nM
The estimate for compound 3 lay 6.4-fold (0.80 log units) above the measured number, within the range that was stated.
By their numbers in this assay, from the lowest: compound 3; then compound 2; then compound 1.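

In this assay, shortening the group on this aromatic carbon, ortho to a methoxy group, kept lowering the number: a 23-fold lower number from compound 2 to compound 3 (1.36 log units; beyond the scatter), and across the whole series, a 500-fold lower number from compound 1 to compound 3 (2.70 log units; beyond the scatter). Compound 3 has selenium directly on the ring and no nitrile, so among these compounds a nitrile on selenium is not needed for a low number. Nothing available explains this fall.

The compounds shown leave open whether the selenium itself matters or only the small size of the group. A methylthio or ethyl group here would help separate the two.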